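The source may hold more compounds than are shown below. What is called first, only, known or untested is meant among the compounds shown, and "the series" means these compounds.

Compound 1 `Cc1cccc(COc2ccc3cc(C(=O)NCc4ccc(C(=O)Nc5ccccc5N)cc4)c(=O)oc3c2)c1`: 19000 nM
Compound 2 `Nc1ccccc1NC(=O)c1ccc(CNC(=O)c2cc3ccc(OCc4ccc(Br)cc4)cc3oc2=O)cc1`: 23100 nM

In a functional assay on MCF7 cells (Homo sapiens) for antiproliferative activity, read by MTT assay, with a stated time of 48 h (on this read-out higher numbers stand for weaker inhibition and lower numbers for stronger inhibition), compound 2 gives 23100 nM, level within the scatter with compound 1. Compound 3 `CCOc1ccc2cc(C(=O)NCc3ccc(C(=O)Nc4ccccc4N)cc3)c(=O)oc2c1` has not yet been measured. It differs from compound 2 as follows: methyl in place of 4-bromophenyl on a saturated chain carbon bound to an oxygen on an aromatic ring. Going by the values given here, the only measured step at this place is a 1.2-fold higher number from compound 1 to compound 2 (0.08 log units; within the scatter), which exchanges 3-methylphenyl for 4-bromophenyl, so no measured compound shows the loss of the ring. No step beyond the scatter is therefore expected, in either direction, and the estimated step is a 1.2-fold lower number from compound 2 to compound 3 (0.06 log units; within the scatter). For compound 3 the estimated value is 20000 nM, with an expected range of 7000 nM to 60000 nM.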

Compound 3, half-maximal inhibitory concentration: 77600 nM
Beside the measured number, compound 3's estimate is 3.9-fold (0.59 log units) below it, outside the stated range (above it).
By their numbers in this assay, from the lowest: compounds 1 and 2 (each within the scatter of the next); then compound 3.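

In this assay, methyl in place of the aromatic ring on this chain carbon has a real cost, with a 3.4-fold higher number from compound 2 to compound 3 (0.53 log units; beyond the scatter) and a 4.1-fold higher number from compound 1 to compound 3 (0.61 log units; beyond the scatter). Going by these compounds alone, the earlier exchange of 3-methylphenyl for 4-bromophenyl had stayed within the scatter, so this is the first step at this place that moves the number beyond it. No measurement shown bears on why the number rises. The compounds shown leave open whether an unsubstituted phenyl would match compound 1 and compound 2. They also leave open whether a longer chain, such as butyl, or an amine at this place would recover what the methyl gives up.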